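Swapping the piperazine substitution on a shared core

A few compounds are considered here, and "the series" means these few. Any claim that something is new, unique, unknown or untested is made for them only; others in the source may bear on it.

In an ADME assay on microsomes from liver (Mus musculus) for metabolic stability, read by LC-MS, with a stated time of 10 min (on this read-out higher numbers stand for a more stable compound and lower numbers for a less stable compound), three compounds have been measured. Compound 1 `CN(C[C@H]1Cc2c(cccc2N2CCN(Cc3ccccn3)CC2)CN1)[C@H]1CCCc2cccnc21` gives 40.4%. Compound 2 `CCCN(C[C@H]1Cc2c(cccc2N2CCNCC2)CN1)[C@H]1CCCc2cccnc21` gives 87.4%. Compound 3 `C[C@@H]1CN(c2cccc3c2C[C@H](CN(C)[C@H]2CCCc4cccnc42)NC3)C[C@H](C)N1` gives 85.6%, which stands second highest of the three: compound 2 lies within the scatter of it, while compound 1 lies far lower, beyond the scatter.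

Compound 4 `CCN1CCN(c2cccc3c2C[C@H](CN(C)[C@H]2CCCc4cccnc42)NC3)CC1` has not yet been measured. It differs from compound 3 in one place: 4-ethylpiperazin-1-yl in place of 3,5-dimethylpiperazin-1-yl on an aromatic carbon. Among the compounds with values here, no measured pair shows this change, so the direction is uncertain. The expected step of a number 20.6 percentage points lower from compound 3 to compound 4 (beyond the scatter) is downward and beyond the scatter, a guess that leans on compound 1 giving the low value of 40.4%. Compound 4 is therefore estimated at 65%, with a range from 40% to 85%.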

Compound 4, percent of the compound remaining: 18.8%
Beside the measured number, compound 4's estimate is 46.2 percentage points above it; measured number below the stated range.
By their numbers in this assay, from the lowest: compound 4; then compound 1; then compounds 3 and 2 (each within the scatter of the next).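

On this aromatic carbon, the piperazine substitution matters greatly: in this assay, 4-ethylpiperazin-1-yl in place of 3,5-dimethylpiperazin-1-yl gives a number 66.8 percentage points lower from compound 3 to compound 4 (beyond the scatter) even though both groups have the same heavy atoms. A smaller substituent on the piperazine nitrogen does not bring stability back, since methyl in place of pyridin-2-yl gives a number 21.6 percentage points lower from compound 1 to compound 4 (beyond the scatter) on the chain carbon bound to that nitrogen. Nothing measured here explains either drop.

As far as these compounds go, whether the ethyl group or the loss of the two methyl groups drives the larger step remains open. An acetyl group on that nitrogen could help separate these two changes.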